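A few compounds are considered here, and "the series" means these few. Any claim that something is new, unique, unknown or untested is made for them only; others in the source may bear on it.

Working notes on the series.

Compound 1 `CCN1CCN(c2cccc3c2CN([C@H](CCCNS(=O)(=O)c2c[nH]cn2)c2ccc(OC)c(OC)c2)C3=O)CC1` carries an (1H-imidazol-4-yl)sulfonyl group on the amine nitrogen of its side chain. Within the data shown here, in a functional assay on RMS13 cells for antagonist activity at Urotensin-2 receptor (Homo sapiens), read by FLIPR and calcium flux, with a stated time of 1 h (a lower number here means a stronger inhibitor, a higher number a weaker inhibitor), compound 1 gives 51 nM, the lowest of the two numbers measured so far. Among the measured compounds shown here, the other measured member, compound 2 `COc1ccc([C@@H](CCCN(C)S(=O)(=O)c2cccs2)N2Cc3c(cccc3N3CCN(C)CC3)C2=O)cc1OC`, differs from compound 1 in more than one place, so no single step connects them; in this assay compound 2 gives 340 nM, a gap beyond the scatter, which says only that compound 1 is the stronger of the two.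

Compound 3 `CCN1CCN(c2cccc3c2CN([C@H](CCCNCc2cccs2)c2ccc(OC)c(OC)c2)C3=O)CC1` has not yet been measured. Its change from compound 1 is (thiophen-2-yl)methyl in place of (1H-imidazol-4-yl)sulfonyl on an amine nitrogen. For the measured compounds named here, no measured pair shows this kind of exchange, so the expected size of the step rests on nothing more than the general range of the series. The step from compound 1 to compound 3 is expected to be a modest loss, a 2.9-fold higher number from compound 1 to compound 3 (0.47 log units; beyond the scatter), though a result within the scatter cannot be ruled out. Compound 3 is thus estimated at 150 nM in this assay, with a range from 40 nM to 600 nM.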

Compound 3, half-maximal inhibitory concentration: 59 nM
Beside the measured number, compound 3's estimate is 2.5-fold (0.41 log units) above it, within the range that was stated.
By their numbers in this assay, from the lowest: compounds 1 and 3 (each within the scatter of the next); then compound 2.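

Among these compounds, on the amine nitrogen of the side chain, the exchange of (1H-imidazol-4-yl)sulfonyl for (thiophen-2-yl)methyl is the first single change that can be read, and in this assay it gives a 1.2-fold higher number from compound 1 to compound 3 (0.06 log units; within the scatter) with no shift beyond the scatter. This position therefore takes two different groups at a similar number: one with a sulfonyl and a hydrogen-bond donor, and one with neither, so within this pair neither feature is required. The data at hand offer nothing that explains why the two groups read alike.

As far as these compounds go, it remains open what the free secondary amine, an acetyl group or a plain benzyl group on this nitrogen would give. Also open, from the compounds shown here alone, is whether the sulfonyl and methyl links matter apart from their rings, which a (thiophen-2-yl)sulfonyl group on the same core would help to separate.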